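The source may hold more compounds than are shown below. What is called first, only, known or untested is meant among the compounds shown, and "the series" means these compounds.

Measured so far in an ADME assay on cells (Hepatocyte, Homo sapiens) for metabolic stability, with a stated time of 30 min; a higher number here means that more of the compound is left, a lower number that less of the compound is left:
compound 1 `O=C(OC1CCC(CN2CCN(c3cc(=O)c4cc(C(F)(F)F)cc([N+](=O)[O-])c4s3)CC2)CC1)c1ccccc1`: 56.4%
compound 2 `O=c1cc(N2CCN(CC3CCC(NS(=O)(=O)c4ccccc4)CC3)CC2)sc2c([N+](=O)[O-])cc(C(F)(F)F)cc12`: 90.8%
compound 3 `O=c1cc(N2CCN(CC3CCCCC3)CC2)sc2c(NO)cc(C(F)(F)F)cc12`: 19.1%

Compound 2, at 90.8%, stands highest of the three, and both other compounds lie beyond the scatter from it. The next compound to be tested is compound 4 `O=C(OC1CCC(CN2CCN(c3cc(=O)c4cc(C(F)(F)F)cc([N+](=O)[O-])c4s3)CC2)CC1)c1ccco1`, which has ((furan-2-yl)carbonyl)oxy in place of (phenylsulfonyl)amino on a saturated ring carbon.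

For the measured compounds named here, one measured step bears on this change: a number 34.4 percentage points higher from compound 1 to compound 2 (beyond the scatter). This large step, beyond the scatter, came with (phenylsulfonyl)amino in place of benzoyloxy at that ring carbon. Compound 4 gives up the same (phenylsulfonyl)amino and takes a carbonyl-oxy group like the benzoyloxy of compound 1, but with a five-membered aromatic ring. Going by the values given here, no measured pair shows what that ring swap alone does. Compound 3, at 19.1%, differs from the others in more than one place, so it offers no direct guide.

A large downward step is therefore expected: a number 38.8 percentage points lower from compound 2 to compound 4 (beyond the scatter). For compound 4 the estimate is 52%, with an expected range of 30% to 72%.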

Compound 4, percent of the compound remaining: 1%
Compound 4: the middle estimate sits 51 percentage points above what was measured, outside the stated range (below it).
By their numbers in this assay, from the lowest: compound 4; then compound 3; then compound 1; then compound 2.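

Within the ester series, the group on the carbonyl carbon at this position turns out to matter a great deal in this assay: furan-2-yl in place of phenyl gives a number 55.4 percentage points lower from compound 1 to compound 4 (beyond the scatter) and leaves almost none of compound 4. The carbonyl-oxy link alone therefore does not fix the level, since compound 1 and compound 4 share it and still lie far apart, and the full change from (phenylsulfonyl)amino gives a number 89.8 percentage points lower from compound 2 to compound 4 (beyond the scatter) as the widest gap seen at this ring carbon. Nothing measured here explains the loss.

From the compounds shown here alone, it remains open whether this low number belongs to furan-2-yl specifically or would also appear with a thiophen-2-yl or pyridin-3-yl group on the same carbonyl. A furan-2-yl group carried on a sulfonylamino link, as in compound 2, would show whether the link can offset the ring.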